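Difluorobenzyl Swap on a Longer-Linker Coumarin Amine

A few compounds are considered here, and "the series" means these few. Any claim that something is new, unique, unknown or untested is made for them only; others in the source may bear on it.

This account concerns a small set of propargylamine coumarins tested in an ADME assay on isolated protein for inhibition of Amine oxidase [flavin-containing] A (Homo sapiens), read by fluorescence and Amplex Red, with stated times of 15 min and 20 min; on this read-out lower numbers stand for stronger inhibition and higher numbers for weaker inhibition. Compound 1 `C#CCN(CCCCOc1ccc2ccc(=O)oc2c1)Cc1ccccc1` gives 89400 nM in this assay. Compound 3 `C#CCN(CCCOc1ccc2ccc(=O)oc2c1)Cc1ccccc1` gives 38600 nM in this assay, and compound 2 `C#CCN(CCCOc1ccc2ccc(=O)oc2c1)Cc1ccc(F)c(F)c1` gives 49200 nM in this assay. The difference between the core of compound 1 and the core of compound 3 is not broken down here. Compound 2 arises from compound 3 by 3,4-difluorophenyl in place of phenyl on a saturated chain carbon bound to an amine nitrogen, and that change made a 1.3-fold higher number from compound 3 to compound 2 (0.11 log units; within the scatter) in this assay.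

Compound 4 `C#CCN(CCCCOc1ccc2ccc(=O)oc2c1)Cc1ccc(F)c(F)c1` has not yet been measured. It arises from compound 1 by 3,4-difluorophenyl in place of phenyl on a saturated chain carbon bound to an amine nitrogen, the same change as that from compound 3 to compound 2, at the same place. Because the step of a 1.3-fold higher number from compound 3 to compound 2 (0.11 log units; within the scatter) was small, compound 4 is expected to sit near compound 1, with an estimated step of a 1.3-fold higher number from compound 1 to compound 4 (0.11 log units; within the scatter) in this assay. The expected value rests on one earlier example of the change alone, on a different core, so the true step could fall on either side of it. Compound 4 is therefore estimated to give 115000 nM in this assay, with a plausible range from 55000 nM to 240000 nM.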

Compound 4, half-maximal inhibitory concentration: 93200 nM
Compound 4: middle estimate off by 1.2-fold (0.09 log units), on the high side; the measured number falls inside the stated range.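

In this assay, for the compounds shown here, putting 3,4-difluorophenyl in place of phenyl on a saturated chain carbon bound to an amine nitrogen gave a 1.0-fold higher number from compound 1 to compound 4 (0.02 log units; within the scatter), so on this second core the swap again produced no step that can be told from the usual scatter. Set beside the earlier example, the change reads alike on the two cores, and in this small series it carried over without a detectable difference: the same change on two cores in this assay, a 1.3-fold higher number (0.11 log units; within the scatter) from compound 3 to compound 2 and a 1.0-fold higher number (0.02 log units; within the scatter) from compound 1 to compound 4, 1.2-fold (0.09 log units) apart, within the scatter of two such steps. Going by these compounds alone, this agreement rests on only two pairs of compounds, and it shows no more than that the step stayed small on both cores; it does not show that the change would stay small on any other core, and steps of this size cannot reveal whether the swap has a real but slight effect.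

The compounds shown leave open how a single fluorine, a chlorine or a methoxy group on the phenyl ring would compare with the 3,4-difluorophenyl group. They also leave open whether the same swap stays as small on a core with a shorter or longer chain, or with a methyl group in place of the propargyl group on the amine nitrogen.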